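This account rests on a few compounds, and the source may have more. Where it says the series, first, only, none or still open, it means among the compounds named here.

Measured compounds:
- Compound 1, `O=C1C[C@H](c2ccc(F)cc2)Oc2cc(F)ccc21`, in an in vitro assay on BTI-TN-5B1-4 cells for inhibition of Amine oxidase [flavin-containing] B (Homo sapiens) (a lower number here means a stronger inhibitor, a higher number a weaker inhibitor), compound 1 gives 150 nM
- Compound 2, `Cc1ccc(C2CC(=O)c3ccc(C)cc3O2)cc1`, in this assay compound 2 gives 500 nM

Going by the values given here, of the two compounds measured so far, compound 1 has the lower number, and the gap between compound 1 and compound 2 is beyond the usual scatter of this assay, so compound 1 is the stronger inhibitor of the pair. Among the compounds with values here, the two compounds differ in several places at once, so no single step between them can be read from their values.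

The next compound, compound 3, `O=C1CC(c2ccc(F)cc2)Oc2cc(F)ccc21`, shares every atom and bond with compound 1 and differs in one way only: the two compounds have the same atoms and bonds; at least one stereo element is drawn with a configuration in one of them and without one in the other: 1 of 1 stereo elements differ; a stereocentre at a saturated ring carbon is drawn R in compound 1 and without a configuration in compound 3. Compound 3 is therefore drawn as a mixture of both configurations at that carbon, while compound 1 is drawn as one of them. Such a mixture contains the form seen in compound 1 alongside its mirror form, whose potency is unknown here. A small step toward a weaker number is expected from compound 1 to compound 3, a 1.7-fold higher number from compound 1 to compound 3 (0.22 log units; within the scatter), and it may well lie within the scatter. Compound 3 is expected to give about 250 nM in this assay, within a range of 120 nM to 600 nM.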

Compound 3, half-maximal inhibitory concentration: 670 nM
Compound 3: middle estimate off by 2.7-fold (0.43 log units), on the low side; measured number above the stated range.
By their numbers in this assay, from the lowest: compound 1; then compounds 2 and 3 (each within the scatter of the next).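

Going by these compounds alone, this pair gives the first step that can be read in this assay, and it shows that a change touching no atom and no bond can still move the number: the change is a 4.5-fold higher number from compound 1 to compound 3 (0.65 log units; beyond the scatter) and so lies beyond the usual scatter. The drawn configuration is the only thing that separates the two compounds, so the step can be traced to this one place: the fact that one of compounds 1 and 3 is drawn with a defined configuration and the other without, at the place where they differ. The saturated ring carbon therefore matters in this assay as a matter of three-dimensional arrangement, not only of which groups are present, and the R form of compound 1 appears to outperform the mixture, which points to a mirror form that contributes less to inhibition.

As far as these compounds go, the potency of the pure mirror form remains open, as does the make-up of the mixture, so the true size of the preference for one configuration cannot be fixed from compound 3 alone. Also open, from the compounds shown here alone, is whether the same preference holds when the fluorine atoms of compound 1 give way to another group, such as a methoxy group or an amine, or when the methyl-bearing compound 2 is resolved into its single forms.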